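The compounds below may be only part of what the source reports. "The series", "measured", "known", "first", "only" and "open" are said of these compounds alone.

Of the compounds shown here, three built on a shared core have been measured in a functional assay on A549 cells (Homo sapiens) for inhibition, read by sulforhodamine B assay; on this read-out higher numbers stand for weaker inhibition of growth and lower numbers for stronger inhibition of growth. Compound 1 `Nc1ccc(CNC(=O)CC2c3ccccc3N=C(N3CCCCC3)N2c2ccccc2)cc1` gives 36600 nM. Compound 2 `CCN1C(N(C)C)=Nc2ccccc2C1CC(=O)NCc1ccc(NS(=O)(=O)c2ccc(C)cc2)cc1` gives 39200 nM. Compound 3 `CCN1C(N2CCCCC2)=Nc2ccccc2C1CC(=O)NCc1ccc(NS(=O)(=O)c2ccc(C)cc2)cc1` gives 23000 nM, and all three numbers sit within the usual scatter of one another, so none of them can be told apart from the rest on these data. For the measured compounds named here, the one change tracked between measured compounds, a 1.7-fold lower number from compound 2 to compound 3 (0.23 log units; within the scatter), swapped a group on a carbon with a double bond to nitrogen and stayed within the scatter.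

Compound 4 `Cc1ccc(S(=O)(=O)Nc2ccc(CNC(=O)CC3c4ccccc4N=C(N4CCCCC4)N3c3ccccc3)cc2)cc1` has not yet been measured. It differs from compound 3 in one place: phenyl in place of ethyl on an amine nitrogen in a ring. Going by the values given here, no measured pair shows this exchange on its own. Compound 1 also carries a phenyl on that ring nitrogen, but it differs from compound 4 at another position as well, so its number only shows that a phenyl there goes together with a value in the same region as compound 3. The single measured step was within scatter, and nothing among the shown numbers points in either direction, so no step beyond the scatter is expected in this assay. Compound 4 is therefore expected to give about 25000 nM, with a range from 10000 nM to 60000 nM. The expected step is a 1.1-fold higher number from compound 3 to compound 4 (0.04 log units; within the scatter).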

Compound 4, concentration for 50% growth inhibition: 3060 nM
Beside the measured number, compound 4's estimate is 8.2-fold (0.91 log units) above it; the whole stated range lies above it.
By their numbers in this assay, from the lowest: compound 4; then compounds 3, 1 and 2 (each within the scatter of the next).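

In this assay, the amine nitrogen in the ring of the shared core turns out to be a position that responds to change: with phenyl in place of ethyl there, the result is a 7.5-fold lower number from compound 3 to compound 4 (0.88 log units; beyond the scatter). The only earlier step, with piperidin-1-yl in place of dimethylamino, was a 1.7-fold lower number from compound 2 to compound 3 (0.23 log units; within the scatter), so this is the first change shown that clearly exceeds the scatter. For the compounds shown here, the (4-methylphenyl)sulfonyl group on the nitrogen on an aromatic ring also matters, giving a 12-fold lower number from compound 1 to compound 4 (1.08 log units; beyond the scatter) when it replaces hydrogen, although this step is seen only with phenyl on the ring nitrogen, just as the phenyl step is seen only with the sulfonyl group present.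

The compounds shown leave open whether the aromatic ring itself goes with the stronger inhibition of growth or whether any larger group would do, a question that cyclohexyl or a longer chain such as butyl on the ring nitrogen could help settle. No evidence is available to explain either step.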